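This account rests on a few compounds, and the source may have more. Where it says the series, first, only, none or still open, it means among the compounds named here.

In a functional assay on HCT-116 cells (Homo sapiens) for inhibition, read by CCK-8 assay, with a stated time of 48 h (a higher number here means a weaker inhibitor, a lower number a stronger inhibitor), three compounds sharing one core have been measured. Compound 1 (`COc1cc(-c2ccnc3cc(-c4c[nH]c5ccccc45)nn23)cc(OC)c1OC`) gives 35 nM, compound 2 (`COc1cc(-c2ccnc3cc(-c4ccc5c(ccn5C)c4)nn23)cc(OC)c1OC`) gives 39 nM, and compound 3 (`COc1cc(-c2ccnc3cc(-c4ccc(C(F)(F)F)cc4)nn23)cc(OC)c1OC`) gives 1860 nM, the highest number of the three and so the weakest inhibitor. Compound 4 (`COc1cc(-c2ccnc3cc(-c4ccc5ccn(C)c5c4)nn23)cc(OC)c1OC`) has not yet been measured. It differs from compound 3 as follows: 1-methyl-1H-indol-6-yl in place of 4-(trifluoromethyl)phenyl on an aromatic carbon. In words, 1-methyl-1H-indol-6-yl stands in place of 4-(trifluoromethyl)phenyl on an aromatic carbon.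

Two large measured steps bear on this change, a 53-fold higher number from compound 1 to compound 3 (1.73 log units; beyond the scatter) and a 48-fold higher number from compound 2 to compound 3 (1.68 log units; beyond the scatter). Each replaces an indolyl group with 4-(trifluoromethyl)phenyl, so the change to compound 4 runs the opposite way. The step of a 1.1-fold higher number from compound 1 to compound 2 (0.05 log units; within the scatter) lies within the scatter, so the two indolyl groups measured so far do not separate. For the measured compounds named here, the 1-methyl-1H-indol-6-yl group itself has no measurement yet, which keeps the range wide. A large step toward a lower number is therefore expected, estimated as a 31-fold lower number from compound 3 to compound 4 (1.49 log units; beyond the scatter). For compound 4 the estimated value is 60 nM, with an expected range of 20 nM to 300 nM.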

Compound 4, half-maximal inhibitory concentration: 1040 nM
Beside the measured number, compound 4's estimate is 17-fold (1.24 log units) below it, and the stated range ends below it.
By their numbers in this assay, from the lowest: compounds 1 and 2 (each within the scatter of the next); then compounds 4 and 3 (each within the scatter of the next).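

In this assay, the change from 1-methyl-1H-indol-5-yl to 1-methyl-1H-indol-6-yl gives a 27-fold higher number from compound 2 to compound 4 (1.43 log units; beyond the scatter), so at this aromatic carbon the point at which the methylindole is joined matters. The step of a 30-fold higher number from compound 1 to compound 4 (1.47 log units; beyond the scatter) is also large, while a 1.8-fold lower number from compound 3 to compound 4 (0.25 log units; within the scatter) lies within the scatter; among these compounds, therefore, the 1-methyl-1H-indol-6-yl group stands with 4-(trifluoromethyl)phenyl, not with the other two indolyl groups. No measurement given here accounts for this difference.

The compounds shown leave open whether the methyl on the indole nitrogen has any bearing on this result, which an unsubstituted 1H-indol-6-yl group would test. They also leave open how a 1-methyl-1H-indol-4-yl group, or an amine on the phenyl ring in place of trifluoromethyl, would behave at this position.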